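Bromo on the phenylsulfonyl group: working notes

This account rests on a few compounds, and the source may have more. Where it says the series, first, only, none or still open, it means among the compounds named here.

In a functional assay on HepG2 cells (Homo sapiens) for cytotoxicity, read by MTT assay, with a stated time of 24 h (on this read-out lower numbers stand for stronger inhibition and higher numbers for weaker inhibition), compound 1 `O=C1/C(=C/c2ccncc2)CN(S(=O)(=O)c2ccccc2)C/C1=C\c1ccccc1F` gives 5800 nM, compound 2 `O=C1/C(=C/c2cccnc2)CN(S(=O)(=O)c2ccccc2)C/C1=C\c1ccccc1C(F)(F)F` gives 5370 nM and compound 3 `O=C1/C(=C/c2ccncc2)CN(S(=O)(=O)c2ccccc2)C/C1=C\c1ccccc1C(F)(F)F` gives 7020 nM. Compound 3 stands level with both neighbours, and the three values cannot be ranked: the measured steps are a 1.2-fold higher number from compound 1 to compound 3 (0.08 log units; within the scatter) and a 1.3-fold higher number from compound 2 to compound 3 (0.12 log units; within the scatter).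

The next structure is compound 4 `O=C1/C(=C/c2ccncc2)CN(S(=O)(=O)c2ccc(Br)cc2)C/C1=C\c1ccccc1C(F)(F)F`. The change is bromo in place of hydrogen on an aromatic carbon, para to a large group, which turns phenylsulfonyl into (4-bromophenyl)sulfonyl (bromo in place of hydrogen on an aromatic carbon).

Neither measured step touches this place. One exchanges fluoro for trifluoromethyl, and the other exchanges pyridin-3-yl for pyridin-4-yl. Among the measured compounds shown here, no measured pair varies the phenylsulfonyl group, so the data give no direct measure of this change. For the measured compounds named here, they show only that both changes made elsewhere on the shared core stayed within the scatter. On that weak basis, no step beyond the scatter is expected, and no direction can be firmly assigned. The expected result of the bromo change is a 1.3-fold lower number from compound 3 to compound 4 (0.11 log units; within the scatter). Compound 4 is estimated at 5500 nM, with an expected range of 2500 nM to 11000 nM.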

Compound 4, half-maximal inhibitory concentration: 14500 nM
The estimate for compound 4 lay 2.6-fold (0.42 log units) below the measured number; measured number above the stated range.
By their numbers in this assay, from the lowest: compounds 2, 1 and 3 (each within the scatter of the next); then compound 4.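

In this assay, among the compounds shown here, the phenylsulfonyl group is the only place so far where a single change moves the number beyond the scatter: bromo in place of hydrogen on an aromatic carbon, para to a large group, gives a 2.1-fold higher number from compound 3 to compound 4 (0.32 log units; beyond the scatter). The exchanges of fluoro for trifluoromethyl and of pyridin-3-yl for pyridin-4-yl stayed within the scatter, so this position responds where those two did not, and the direction here is toward weaker inhibition, although the step is modest and rests on one pair. Nothing available on these compounds accounts for the step.

An amine or a carboxylic acid at the same place would show whether the step belongs to bromo in particular or extends to other groups on the phenyl of the phenylsulfonyl group. On these data alone, it also remains open whether bromo would give a step of similar size and direction on compound 1 or compound 2, whose other groups differ from those of compound 3.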